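Pyridin-2-yl in place of 5-fluoro-2-methoxyphenyl: working notes

This account rests on a few compounds, and the source may have more. Where it says the series, first, only, none or still open, it means among the compounds named here.

In an ADME assay on microsomes from liver (Canis lupus familiaris) for metabolic stability, read by LC-MS, using NADPH, with a stated time of 10 min, tested at 0.1 uM (a lower number here means slower removal, a higher number faster removal of the compound), compound 1 `COc1ccc(F)cc1N1C(=O)CSC1c1cccc(C(=O)NCCCCn2cccn2)c1` gives 480 mL.min-1.g-1 against compound 3 `Cc1cccc(N2C(=O)CSC2c2cccc(C(=O)NCCCCc3ccccc3)c2)c1` at 749 mL.min-1.g-1 and compound 2 `COc1ccc(F)cc1N1C(=O)CSC1c1cccc(C(=O)NCCCCc2ccccc2)c1` at 1650 mL.min-1.g-1. Compound 1 and compound 3 lie within the scatter of each other, and only compound 2 stands clearly apart from both.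

Compound 4 `O=C(NCCCCn1cccn1)c1cccc(C2SCC(=O)N2c2ccccn2)c1` keeps the 1H-pyrazol-1-yl chain of compound 1 and changes one group: pyridin-2-yl in place of 5-fluoro-2-methoxyphenyl on an amide-type nitrogen in a ring.

For the measured compounds named here, two measured steps bear on this. The closer one, a 2.2-fold lower number from compound 2 to compound 3 (0.34 log units; beyond the scatter), has 3-methylphenyl replacing the same group at the same place, though with phenyl at the chain end. The other, a 3.4-fold higher number from compound 1 to compound 2 (0.54 log units; beyond the scatter), concerns the chain end and shows that the change there is not neutral in this assay. Going by the values given here, no measured pair makes the aryl change on the 1H-pyrazol-1-yl chain, and pyridin-2-yl itself is untested, so any transfer is uncertain.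

For compound 4 a small downward move is expected, taken from the direction of the compound 3 step and estimated as a 1.6-fold lower number from compound 1 to compound 4 (0.20 log units; within the scatter). Compound 4 is expected at 300 mL.min-1.g-1 within an estimated range from 130 mL.min-1.g-1 to 650 mL.min-1.g-1.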

Compound 4, intrinsic clearance in microsomes: 88.9 mL.min-1.g-1
Compound 4: the middle estimate sits 3.4-fold (0.53 log units) above what was measured; the whole stated range lies above it.
By their numbers in this assay, from the lowest: compound 4; then compounds 1 and 3 (each within the scatter of the next); then compound 2.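

In this assay, the step of a 5.4-fold lower number from compound 1 to compound 4 (0.73 log units; beyond the scatter) shows that, with the 1H-pyrazol-1-yl chain held constant, the group on the amide-type nitrogen in a ring still moves this number beyond the scatter. Set beside a 2.2-fold lower number from compound 2 to compound 3 (0.34 log units; beyond the scatter), which has phenyl at the chain end, it gives two replacements of 5-fluoro-2-methoxyphenyl at this place, on two different chain ends, and both lower the number, with neither pair going against that direction. Nothing measured here bears on what lies behind the step from 5-fluoro-2-methoxyphenyl to pyridin-2-yl.

The compounds shown leave open whether this step follows from the ring nitrogen of pyridin-2-yl or from the departure of the methoxy and fluoro groups, a question that unsubstituted phenyl or pyridin-3-yl at the same place would help to separate. Also open, on these data alone, is whether pyridin-2-yl lowers the number to a similar extent when paired with the phenyl chain end of compound 2, or with a shorter chain between the amide nitrogen and the 1H-pyrazol-1-yl group.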